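Hydroxamate series, aryl sulfonyl variation, MCF7 growth inhibition

The source may report more compounds than this note shows. Statements on the series, on what has been measured and on what is new or still open speak of the compounds shown alone.

Measured compounds and values in a functional assay on MCF7 cells (Homo sapiens) for antiproliferative activity; a higher number here means a weaker inhibitor of growth, a lower number a stronger inhibitor of growth:
compound 1 `O=C(NO)c1cnc(N2CCN(S(=O)(=O)c3ccccc3)CC2)s1` gives 10000 nM
compound 2 `O=C(/C=C/c1cnc(N2CCN(S(=O)(=O)c3ccc(-c4ccccc4)cc3)CC2)s1)NO` gives 1500 nM
compound 3 `O=C(/C=C/c1cnc(N2CCN(S(=O)(=O)c3ccc(C(F)(F)F)cc3)CC2)s1)NO` gives 3000 nM

Compound 3 stands second highest of the three numbers in this assay. Its nearest neighbour is compound 2, separated by a step within the scatter; the furthest is compound 1, whose number lies beyond the scatter from that of compound 3.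

Compound 4 `O=C(/C=C/c1cnc(N2CCN(S(=O)(=O)c3ccccc3)CC2)s1)NO` is not yet measured. The change from compound 3 is hydrogen in place of trifluoromethyl on an aromatic carbon. Among the compounds with values here, the one step that bears on this position is a 2.0-fold higher number from compound 2 to compound 3 (0.30 log units; within the scatter), which exchanged two substituents on the same aromatic carbon without leaving the scatter. Compound 1 carries the same unsubstituted phenyl sulfonyl as compound 4 but differs in how the hydroxamate is joined to the core, so its value does not read directly across.

On this basis compound 4 is expected to show no step beyond the scatter, no change at the digits printed from compound 3 to compound 4 (within the scatter). The estimate for compound 4 in this assay is 3000 nM, with a range from 1200 nM to 8000 nM.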

Compound 4, concentration for 50% growth inhibition: 3000 nM
For compound 4 middle estimate and measured number coincide at the digits printed, and the stated range covers the measured number.
By their numbers in this assay, from the lowest: compounds 2, 3 and 4 (each within the scatter of the next); then compound 1.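

In this assay, hydrogen in place of trifluoromethyl gives no change at the digits printed from compound 3 to compound 4 (within the scatter) and hydrogen in place of phenyl gives a 2.0-fold higher number from compound 2 to compound 4 (0.30 log units; within the scatter) so an unsubstituted ring now joins the two substituted ones, and all three groups on this aromatic carbon lie within the scatter of one another. The same compound also supplies the first one-place comparison for the hydroxamate end: 2-(hydroxycarbamoyl)ethenyl in place of hydroxycarbamoyl gives a 3.3-fold lower number from compound 1 to compound 4 (0.52 log units; beyond the scatter) and this is the only change shown that goes beyond the scatter. Nothing at hand explains either result.

Going by these compounds, whether an amine or a carboxylic acid on the same aromatic carbon would leave the scatter stays open. So does the effect of a longer chain carrying the hydroxycarbamoyl group.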